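The source may report more compounds than this note shows. Statements on the series, on what has been measured and on what is new or still open speak of the compounds shown alone.

Series notes. Three compounds have readings in a functional assay on C6 cells (Rattus norvegicus) for cytotoxicity, read by MTT assay, with a stated time of 24 h, tested at 6 ug/mL; on this read-out lower numbers stand for a stronger effect and higher numbers for a weaker effect at the one concentration tested. Compound 1 `O=C(CSc1nnnn1-c1ccccc1)N/N=c1/scc(-c2ccc(Br)cc2)n1-c1ccccc1` gives 61.8% and stands lowest of the three numbers shown. Compound 3 `Cc1ccc(-c2cs/c(=N/NC(=O)CSc3nncn3C)n2-c2ccccc2)cc1` gives 74.6%, a number that lies beyond the scatter above compound 1. Compound 2 `Cc1nnc(SCC(=O)N/N=c2/scc(-c3ccc(Cl)cc3)n2-c2ccccc2)s1` gives 82.8%, further still from compound 1 and also beyond the scatter. No two of these three compounds differ in one place only, so no single step can be read off between measured compounds, and the cores of compound 2 and compound 3 are not those of compound 1.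

Compound 4 `O=C(CSc1nnnn1-c1ccccc1)N/N=c1/scc(-c2ccc(F)cc2)n1-c1ccccc1` is not yet measured. It differs from compound 1 by fluoro in place of bromo on an aromatic carbon; the change sits on an aromatic carbon of a six-membered aromatic ring of carbon only, para to a large group. Within the data shown here, no measured pair shows fluoro against bromo on a shared core, so the size of this step rests on no data. Expected is a step of a number 10.2 percentage points higher from compound 1 to compound 4 (beyond the scatter), toward a higher number, of a size near the edge of the scatter. For compound 4 the expected value in this assay is 72%, within a range from 58% to 88%.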

Compound 4, a percentage reported as activity, at one concentration (the size of the read-out at that concentration, not a potency): 74.9%
Compound 4: middle estimate off by 2.9 percentage points, on the low side; low and high end bracket the measured number.
By their numbers in this assay, from the lowest: compound 1; then compounds 3, 4 and 2 (each within the scatter of the next).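

On the core of compound 1, the halogen on this aromatic carbon, para to a large group, is not neutral in this assay: fluoro in place of bromo gives a number 13.1 percentage points higher from compound 1 to compound 4 (beyond the scatter). Among these compounds, this is the first single-place comparison, and it puts a measured size on a change that the earlier compounds, all on differing cores, could not isolate. No measurement at hand speaks to what lies behind this step.

Among the compounds shown here, only this one pair carries the change, so whether the step holds on any other core remains open. Going by these compounds, how a methoxy group, an amine or a carboxylic acid on the same carbon would read against bromo and fluoro also remains open.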